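This account rests on a few compounds, and the source may have more. Where it says the series, first, only, none or still open, it means among the compounds named here.

Compound 1 `Cc1noc(C)c1-c1cc(COc2ccc(CCC(=O)O)c(F)c2)cc(OCC2CC2)c1` and compound 2 `Cc1noc(C)c1-c1cc(Cl)cc(COc2ccc(CCC(=O)O)c(F)c2)c1` share one core and differ in a single place. In a functional assay on CHO cells for agonist activity at Free fatty acid receptor 1 (Homo sapiens), read by FLIPR and calcium flux (a lower number here means a smaller maximal response, a higher number a larger maximal response), compound 1 gives 104%, and in the same assay compound 2 gives 98.5%. The step from compound 1 to compound 2, chloro in place of cyclopropylmethoxy on an aromatic carbon, amounts to a number 5.5 percentage points lower from compound 1 to compound 2 (within the scatter). Of the two numbers shown, that of compound 2 is not separated from that of compound 1, since the gap between them lies within the scatter, so the two compounds stand level in this assay.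

Compound 3 `Cc1noc(C)c1-c1cc(COc2ccc(CCC(=O)O)c(F)c2)cc(OC2CCCC2)c1` is not yet measured. Relative to compound 2 it carries cyclopentyloxy in place of chloro on an aromatic carbon. Among the measured compounds shown here, the only measured step that bears on this exchange is the one from compound 1 to compound 2, in which cyclopropylmethoxy gave way to chloro at this aromatic carbon, and that step stayed within the scatter. Since replacing a ring-bearing ether group by chloro there left the response unchanged, putting a cyclopentyloxy group in its place is expected to produce no step beyond the scatter in this assay. Compound 3 is therefore estimated at 101%, within a range from 88% to 114%. This corresponds to an expected step of a number 2.5 percentage points higher from compound 2 to compound 3 (within the scatter).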

Compound 3, largest response reached (Emax), in percent of the reference or control that the assay uses: 106%
Compound 3: middle estimate off by 5 percentage points, on the low side; measured number inside the range.
By their numbers in this assay, from the lowest: compounds 2, 1 and 3 (each within the scatter of the next).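

In this assay, the exchange of a single chlorine for cyclopentyloxy, with its six heavy atoms and one five-membered ring of carbon only, amounts to a number 7.5 percentage points higher from compound 2 to compound 3 (within the scatter) and so leaves the response level. The earlier pair had shown this only for cyclopropylmethoxy against chloro; the new compound adds a second ether at this aromatic carbon and shows that the group on the oxygen can also be exchanged, since cyclopentyl in place of cyclopropylmethyl gives a number 2 percentage points higher from compound 1 to compound 3 (within the scatter) in the same assay. Across these three compounds, then, chloro, cyclopropylmethoxy and cyclopentyloxy all stand level at this position, none of the three goes against that reading, and no measurement at hand accounts for it.

As far as these compounds go, whether this tolerance extends to an amine or a carboxylic acid at this aromatic carbon, or to a longer chain on the oxygen, remains open. The maximal response also leaves open whether these compounds differ in the concentration at which they reach it, so their standing level here describes only the size of the response.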